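Methyl for Cyano on Selenium: Three Measured, One Expected

The source may report more compounds than this note shows. Statements on the series, on what has been measured and on what is new or still open speak of the compounds shown alone.

Compound 1, `COc1ccc(N(C)c2nc(C)nc3ccccc23)cc1[Se]C`: 28 nM
Compound 2, `Cc1nc(N(C)c2ccc([Se]C#N)c(Cl)c2)c2ccccc2n1`: 12 nM
Compound 3, `COc1ccc(N(C)c2nc(C)nc3ccccc23)cc1[Se]C#N`: 34 nM

Of the compounds shown here, three have been measured in a functional assay on HCT-116 cells (Homo sapiens) for inhibition, read by MTT assay, with a stated time of 48 h; on this read-out lower numbers stand for stronger inhibition and higher numbers for weaker inhibition. Compound 2 gives the lowest number of the three; the step from it to compound 1 and the step to compound 3 both lie beyond the scatter. Compound 3 and compound 1 differ in one place, (methyl in place of cyano on a selenium), and the change gave a 1.2-fold lower number from compound 3 to compound 1 (0.08 log units; within the scatter).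

Compound 4, `C[Se]c1ccc(N(C)c2nc(C)nc3ccccc23)cc1Cl`, has not yet been measured. Within the data shown here, it is related to compound 2 by methyl in place of cyano on a selenium, the same change as the one from compound 3 to compound 1, at a selenium with the same neighbour in both pairs. The difference between the core of compound 2 and the core of compound 3 is not broken down here.

Compound 4 is therefore expected to stay close to compound 2 in this assay, with a step of about a 1.1-fold lower number from compound 2 to compound 4 (0.04 log units; within the scatter), resting on the step from compound 3 to compound 1, which was within the scatter. The estimate for compound 4 is 11 nM, between 5 nM and 25 nM.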

Compound 4, half-maximal inhibitory concentration: 5 nM
Compound 4: the middle estimate sits 2.2-fold (0.34 log units) above what was measured; low and high end bracket the measured number.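

In this assay, methyl in place of cyano on a selenium gave a 2.4-fold lower number from compound 2 to compound 4 (0.38 log units; beyond the scatter), a modest step that lies beyond the scatter, whereas the same change on the core of compound 3 stayed within it. Set side by side, the two steps do not differ by more than the scatter of two such steps allows, so the change carries from one core to the other in this series without a measurable difference in its size: the same change on two cores in this assay, a 1.2-fold lower number (0.08 log units; within the scatter) from compound 3 to compound 1 and a 2.4-fold lower number (0.38 log units; beyond the scatter) from compound 2 to compound 4, 2.0-fold (0.30 log units) apart, within the scatter of two such steps This does not show that the step is truly the same on both cores or that the core has no influence on it, and two pairs say nothing about other cores or about why either step has its size.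

The compounds shown leave open how an ethyl chain, or a longer chain ending in an amine, on the selenium would compare with methyl and cyano. They also leave open whether the step would hold on a core carrying fluorine in place of the chlorine of compound 2.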